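Removing an isopropyl group from compound 2

The source may report more compounds than this note shows. Statements on the series, on what has been measured and on what is new or still open speak of the compounds shown alone.

- Compound 1 `C[C@@]1([C@H](OC(=O)c2cnc3ccccc3n2)C(N)=O)CO1` reads > 25000 nM (a limit)
- Compound 2 `CCOC(=O)[C@@H](NC(=O)[C@@H](OC(=O)c1ccc(C)c2cc(OC)ccc12)[C@]1(C)CO1)C(C)C` reads 350 nM (a number)

For the measured compounds named here, in a functional assay on A2780 cells (Homo sapiens) for cytotoxicity (on this read-out higher numbers stand for weaker inhibition and lower numbers for stronger inhibition), compound 2 gives 350 nM as the only true number so far. For compound 1 the entry > 25000 nM is a limit of the assay, not a number. Compound 3 `CCOC(=O)CNC(=O)[C@@H](OC(=O)c1ccc(C)c2cc(OC)ccc12)[C@]1(C)CO1` differs from compound 2 in one place only (hydrogen in place of isopropyl on a saturated chain carbon bound to an amide-type nitrogen and a carbonyl carbon), where hydrogen replaces isopropyl on a saturated chain carbon. Going by the values given here, no measured pair shows this change on its own, so the data give no direct guide to its size. The expected change is a 2.3-fold higher number from compound 2 to compound 3 (0.36 log units; beyond the scatter) in this assay as a moderate step towards weaker inhibition, though a result close to compound 2 remains possible. For compound 3 the estimated value is 800 nM with an expected range from 200 nM to 3500 nM in this test.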

Compound 3, half-maximal inhibitory concentration: 340 nM
Beside the measured number, compound 3's estimate is 2.4-fold (0.37 log units) above it, within the range that was stated.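

In this assay the change reads a 1.0-fold lower number from compound 2 to compound 3 (0.01 log units; within the scatter). For the compounds shown here, on a saturated chain carbon bound to an amide-type nitrogen and a carbonyl carbon, isopropyl and hydrogen therefore cannot be told apart in this test, so the three carbons of the isopropyl group are not needed for compound 3 to match compound 2, something the earlier compounds could not show because no measured pair isolated this change. No data shown bear on why the two compounds read alike.

The compounds shown leave open whether this carbon accepts other groups, since a benzyl group, a longer chain or an amine might give a different reading. They also leave open whether a carboxylic acid in place of the ethoxycarbonyl group would match these compounds.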